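Pyrimidin-2-yl in place of 4-fluorophenyl: working notes

This account rests on a few compounds, and the source may have more. Where it says the series, first, only, none or still open, it means among the compounds named here.

Values in a functional assay on MCF7 cells (Homo sapiens) for antiproliferative activity, read by MTT assay, with a stated time of 72 h; on this read-out higher numbers stand for weaker inhibition and lower numbers for stronger inhibition
- compound 1 `Cc1ccccc1N1CCN(C(=S)SCc2ccc3nc(N)nc(N)c3c2)CC1` gives 4230 nM
- compound 2 `Nc1nc(N)c2cc(CSC(=S)N3CCN(c4ccc(Cl)c(Cl)c4)CC3)ccc2n1` gives 2370 nM
- compound 3 `Nc1nc(N)c2cc(CSC(=S)N3CCN(c4ccc(F)cc4)CC3)ccc2n1` gives 1920 nM

Compound 3 stands at the low end of these numbers, within the scatter of compound 2 (a 1.2-fold lower number from compound 2 to compound 3 (0.09 log units; within the scatter)) and modestly clear of compound 1 (a 2.2-fold lower number from compound 1 to compound 3 (0.34 log units; beyond the scatter)). Compound 4 `Nc1nc(N)c2cc(CSC(=S)N3CCN(c4ncccn4)CC3)ccc2n1` carries pyrimidin-2-yl in place of 4-fluorophenyl on an amine nitrogen in a ring. For the measured compounds named here, the steps that bear on this are the two above and one more at the same nitrogen (a 1.8-fold lower number from compound 1 to compound 2 (0.25 log units; within the scatter)), and all are small. Going by the values given here, no measured compound has hetero atoms in the ring at this place, so the direction remains uncertain. A slight rise is expected, with no step beyond the scatter (a 1.5-fold higher number from compound 3 to compound 4 (0.16 log units; within the scatter)). For compound 4 the estimated value is 2800 nM (expected range 1200 nM to 6500 nM).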

Compound 4, half-maximal inhibitory concentration: 4190 nM
Estimate against measurement, compound 4: 1.5-fold (0.18 log units) below; low and high end bracket the measured number.
By their numbers in this assay, from the lowest: compounds 3, 2, 4 and 1 (each within the scatter of the next, the first and the last beyond it).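

In this assay, pyrimidin-2-yl, the only ring here with hetero atoms at this amine nitrogen, reads modestly weaker than 4-fluorophenyl (a 2.2-fold higher number from compound 3 to compound 4 (0.34 log units; beyond the scatter)), so this place does respond to the ring it carries. The same group stays within the scatter of 3,4-dichlorophenyl (a 1.8-fold higher number from compound 2 to compound 4 (0.25 log units; within the scatter)) and of 2-methylphenyl (a 1.0-fold lower number from compound 1 to compound 4 (0.00 log units; within the scatter)), so it separates only from 4-fluorophenyl. Nothing at hand accounts for this step.

Going by these compounds, whether the step follows the ring nitrogens or the departure of fluorine stays open; unsubstituted phenyl and pyridin-2-yl at this nitrogen would bear on that.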